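Amine-for-ether exchange on the ring nitrogen of the core

This account rests on a few compounds, and the source may have more. Where it says the series, first, only, none or still open, it means among the compounds named here.

Measured compounds:
- compound 1 `COCC(C)(C)Nc1nc(C)nc2c1nnn2-c1ccc(C(C)C)cc1Br`: 195 nM
- compound 2 `CCCC(CN(C)C)Nc1nc(C)nc2c1nnn2-c1ccc(C(C)C)cc1Br`: 38.7 nM

In an in vitro assay on 293-EBNA cells for binding affinity to corticotropin-releasing factor receptor 1 (Homo sapiens) (on this read-out higher numbers stand for weaker inhibition and lower numbers for stronger inhibition), compound 2 gives 38.7 nM, the lowest of the two numbers in hand; compound 1, which shares the core, gives 195 nM. Among the measured compounds shown here, the only step recorded is a 5.0-fold lower number from compound 1 to compound 2 (0.70 log units; beyond the scatter), a chain carrying a nitrogen in place of one carrying an oxygen on the ring nitrogen.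

Compound 3 `COCCNc1nc(C)nc2c1nnn2-c1ccc(C(C)C)cc1Br` is not yet measured. It differs from compound 2 by a group of 4 heavy atoms (3 carbon, 1 oxygen; no ring) in place of a group of 8 heavy atoms (7 carbon, 1 nitrogen; no ring), on a nitrogen on an aromatic ring. For the measured compounds named here, this reverses the direction of the one known step: the nitrogen-bearing chain goes out and an oxygen-bearing one, shorter than that of compound 1, comes in. Because a 5.0-fold lower number from compound 1 to compound 2 (0.70 log units; beyond the scatter) was beyond the scatter, a step in this assay back towards the number of compound 1 is expected, of size a 6.5-fold higher number from compound 2 to compound 3 (0.81 log units; beyond the scatter).

For compound 3 the estimate in this assay is 250 nM, with a range of 80 nM to 800 nM.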

Compound 3, inhibition constant: 242 nM
For compound 3 the middle estimate is 1.0-fold (0.01 log units) above the measured one; the range from low to high includes it.
By their numbers in this assay, from the lowest: compound 2; then compounds 1 and 3 (each within the scatter of the next).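

In this assay, 2-methoxyethyl in place of the nitrogen-bearing chain on the nitrogen on an aromatic ring gives a 6.3-fold higher number from compound 2 to compound 3 (0.80 log units; beyond the scatter) and so gives up the lower number seen with compound 2. The two oxygen-bearing chains are not told apart: 2-methoxyethyl in place of 1-(methoxymethyl)-1-methylethyl gives a 1.2-fold higher number from compound 1 to compound 3 (0.09 log units; within the scatter) and thus no change, so among the three compounds only the nitrogen-bearing chain stands apart from the other two. No measurement at hand bears on the origin of these steps.

Compound 2 differs from the other two compounds both in the chain atom that carries the difference, nitrogen for oxygen, and in chain size, and these two changes remain unseparated. Open as well is how a plain alkyl chain, a morpholine or a carboxylic acid would behave on this nitrogen.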